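Benzoyl in place of butanoyl on a triazene amide

The source may hold more compounds than are shown below. What is called first, only, known or untested is meant among the compounds shown, and "the series" means these compounds.

Measured so far:
compound 1 `CCCC(=O)N[C@@H](C)C(=O)N(C)/N=N/c1ccc(C#N)cc1` gives 9.1 h in a physicochemical assay for metabolic stability, read by HPLC, in phosphate buffer, at pH 7.7; on this read-out lower numbers stand for a shorter-lived compound and higher numbers for a longer-lived compound
compound 2 `CC(=O)N[C@@H](C)C(=O)N(C)/N=N/c1ccc(C(C)=O)cc1` gives 13.9 h in this assay

The two measured compounds share a core in which an amide-linked alanine unit carries the triazene. Compound 1 stands at the lowest of the two numbers in this assay, and its nearest neighbour is compound 2, whose number is higher by an amount that stays within the usual scatter of this kind of measurement; the two values therefore cannot be ordered with confidence.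

Compound 3 `C[C@H](NC(=O)c1ccccc1)C(=O)N(C)/N=N/c1ccc(C#N)cc1` has not yet been measured in this assay. It differs from compound 1 in one place: phenyl in place of propyl on a carbonyl carbon. Among the compounds with values here, no pair of measured compounds shows this exchange, so nothing in the data says how large a step it brings. The account expects no step beyond the scatter: from compound 1 to compound 3 the expected change in this assay is a 1.1-fold higher number from compound 1 to compound 3 (0.04 log units; within the scatter). For compound 3 the estimate in this assay is 10 h, with a range from 5 h to 20 h.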

Compound 3, half-life: 9.2 h
Compound 3: the middle estimate sits 1.1-fold (0.04 log units) above what was measured; the measured number falls inside the stated range.
By their numbers in this assay, from the lowest: compounds 1, 3 and 2 (each within the scatter of the next).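

Within the data shown here, the exchange of propyl for phenyl on a carbonyl carbon gives the first step at this position that can be read on its own, since compounds 1 and 2 differ in more than one place and so could not isolate it. In this assay the step is a 1.0-fold higher number from compound 1 to compound 3 (0.00 log units; within the scatter), which shows that, on the core of compound 1, this open chain and this six-membered aromatic ring of carbon only cannot be told apart by half-life, even though the entering group is the larger by heavy-atom count. No measurement shown here accounts for this result.

As far as these compounds go, what remains open is whether this position tolerates every exchange equally, since a single step says nothing about a carboxylic acid, an amine or a much longer alkyl chain on the same carbonyl carbon. From the compounds shown here alone, it is also open whether phenyl in place of the chain would give a step of similar size on the core of compound 2, where the group on the carbonyl carbon is methyl and the other substituent differs as well.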